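Hydrogen to methyl on compound 1: working notes

The compounds below may be only part of what the source reports. "The series", "measured", "known", "first", "only" and "open" are said of these compounds alone.

- compound 1 `O=C1C=CC(O)(c2cc3ccccc3n2S(=O)(=O)c2ccccc2)C=C1`: 39 nM
- compound 2 `O=C1C=CC(O)(c2cc3ccc(F)cc3n2S(=O)(=O)c2ccccc2)C=C1`: 16 nM

Going by the values given here, in a functional assay on NCI60 cells (Homo sapiens) for inhibition (on this read-out lower numbers stand for stronger inhibition of growth and higher numbers for weaker inhibition of growth), compound 1 holds the higher of the only two numbers so far, and compound 2 is its sole neighbour. The next structure is compound 3 `Cc1ccc(S(=O)(=O)n2c(C3(O)C=CC(=O)C=C3)cc3ccccc32)cc1`, which differs from compound 1 as follows: methyl in place of hydrogen on an aromatic carbon. In words, this is methyl in place of hydrogen on an aromatic carbon, or phenyl to 4-methylphenyl.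

Among the compounds with values here, one measured step bears on this change: a 2.4-fold lower number from compound 1 to compound 2 (0.39 log units; beyond the scatter). That step is modest, though beyond the scatter, and it also replaces hydrogen on an aromatic carbon. Within the data shown here, it brings in fluoro, however, and no measured step involves methyl, so it offers only a loose guide to size and none to direction. A modest step at most is therefore expected in this assay, with no shift beyond the scatter in either direction. The estimated step is a 1.1-fold lower number from compound 1 to compound 3 (0.05 log units; within the scatter). For compound 3 the expected value is 35 nM, with an estimated range of 15 nM to 80 nM.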

Compound 3, concentration for 50% growth inhibition: 110 nM
Compound 3: middle estimate off by 3.1-fold (0.50 log units), on the low side; measured number above the stated range.
By their numbers in this assay, from the lowest: compound 2; then compound 1; then compound 3.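

Notes on the phenyl to 4-methylphenyl change: in this assay methyl on this aromatic carbon, para to a large group, gives a 2.8-fold higher number from compound 1 to compound 3 (0.45 log units; beyond the scatter) and so marks the first measured change in the series that moves the number upward. Going by these compounds alone, the only earlier step, a 2.4-fold lower number from compound 1 to compound 2 (0.39 log units; beyond the scatter), went the other way with fluoro at a different place on the structure, so replacing hydrogen on an aromatic carbon can move the number in either direction here, although these two steps differ in both the group and the place and do not isolate either one. Nothing at hand accounts for the higher number of compound 3.

Open, from the compounds shown here alone, is whether a fluoro, a methoxy, an amine or a carboxylic acid on this same carbon would also raise the number, and whether a longer chain such as ethyl would move it further than methyl does. Also open, going by these compounds, is what methyl would do at the place that carries fluoro in compound 2, and whether the steps of the two changes would add up if both groups stood on one structure.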